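Two Isomers at the Limit, a Third One Estimated

This account rests on a few compounds, and the source may have more. Where it says the series, first, only, none or still open, it means among the compounds named here.

Compound 1, with the structure `COc1cc(-c2ncnn2-c2ccc(Cl)cc2Cl)cc(OC)c1OC`, was tested in a functional assay on K562 cells (Homo sapiens) for antiproliferative activity, read by MTT assay, with a stated time of 72 h; on this read-out lower numbers stand for stronger inhibition and higher numbers for weaker inhibition. In this assay compound 1 gives only a limit, > 10000 nM, not a number. The closely related compound 2, `COc1cc(-n2ncnc2-c2ccc(Cl)c(Cl)c2)cc(OC)c1OC`, was tested in the same way. In this assay compound 2 also gives only a limit, > 10000 nM. So compound 1 stands where every value shown stands: at the limit of > 10000 nM in this assay, at which 2 of the 2 values shown sit, with nothing measured beyond it.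

Compound 3, `COc1cc(-c2ncnn2-c2ccc(Cl)c(Cl)c2)cc(OC)c1OC`, has not yet been measured. It is built from the same atoms as compound 1, joined differently: 3,4-dichlorophenyl in place of 2,4-dichlorophenyl on an aromatic nitrogen. Among the measured compounds shown here, no step between two measured compounds is available here, so the size of this change has to be guessed. Because both compounds shown sit at the limit of > 10000 nM in this assay, at which 2 of the 2 values shown sit, the expectation is that compound 3 behaves the same way, with a step from compound 1 that stays within the usual scatter and most likely only another limit being reported.

The estimate for compound 3 in this assay is therefore 20000 nM, with a range from 5000 nM to 100000 nM, which corresponds to an expected step that the limit leaves unreadable from compound 1 to compound 3.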

Compound 3, half-maximal inhibitory concentration: > 10000 nM
Compound 3 gave a limit, no number; the forecaster's own chance of this, stated with the estimate: 85%; the middle value is on the limit's open side.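

In this assay compound 3 gives only a limit, > 10000 nM. No step can be read between compound 1 and compound 3, since both give only limits: the limit of > 10000 nM in this assay, at which 3 of the 3 values shown sit.

The compounds shown leave open how strongly any of them inhibits K562 cells, and whether 3,4-dichlorophenyl and 2,4-dichlorophenyl differ at all.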